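Swapping the biaryl tail for a sulfamoyl on the shared core

This account rests on a few compounds, and the source may have more. Where it says the series, first, only, none or still open, it means among the compounds named here.

The three measured compounds share the core of compound 1 `CCc1ccc(-c2ccc(NC3=CC(=O)c4ncncc4C3=O)cc2)cc1`, which in a functional assay on MIA PaCa-2 cells (Homo sapiens) for cytotoxicity, read by MTT assay, with a stated time of 72 h (on this read-out lower numbers stand for stronger inhibition and higher numbers for weaker inhibition), gives 2000 nM. Compound 3 `O=C1C(NCc2ccc(F)cc2)=CC(=O)c2ncncc21` gives 1700 nM in this assay, and the two numbers lie within the scatter of each other, so neither can be placed ahead of the other. Going by the values given here, compound 2 `O=C1C(Nc2cccc(B(O)O)c2)=CC(=O)c2ncncc21` reaches only a limit of this assay, > 10000 nM, and so reports no number; it is the one value that sits at the limit of > 10000 nM in this assay, at which 1 of the 3 values shown sits. Compound 1 therefore stands with the highest of the two numbers shown, but only within the scatter of its neighbour.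

Compound 4 `NS(=O)(=O)c1ccc(NC2=CC(=O)c3ncncc3C2=O)cc1` has not yet been measured. It differs from compound 1 in one place: sulfamoyl in place of 4-ethylphenyl on an aromatic carbon. Among the compounds with values here, no measured pair in this set changes the same position, so the size of the step is open. Given that compound 2, the one compound here without the aryl tail, gives > 10000 nM, the step from compound 1 to compound 4 is expected to move toward weaker inhibition, a 3.0-fold higher number from compound 1 to compound 4 (0.48 log units; beyond the scatter), rather than to stay within the scatter. Compound 4 is thus estimated at 6000 nM in this assay, with a range from 2000 nM to 20000 nM, and a real chance that only a limit is reported.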

Compound 4, half-maximal inhibitory concentration: > 10000 nM
Compound 4: only a limit was reported; the forecaster's own chance of this, stated with the estimate: 35%; middle value at least 1.6-fold (0.22 log units) from the limit.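

On this aromatic carbon, para to a large group, this assay now gives a first readable step: sulfamoyl in place of 4-ethylphenyl gives an at least 5.0-fold higher number from compound 1 to compound 4 (0.69 log units; beyond the scatter), so the position does not accept every group that can be placed there. Compound 4 gives > 10000 nM, which is a limit of the assay and not a number, so the printed step is only a lower bound on the true size of the change. Compound 4 also joins compound 2 at that limit, leaving both without a number: the limit of > 10000 nM in this assay, at which 2 of the 4 values shown sit.

The compounds shown leave open which part of the exchange matters, since this one step removes a six-membered aromatic ring of carbon only and brings in a group with no ring, while the hydrogen-bond donors and acceptors change with it. A plain phenyl, a methoxy or a carboxylic acid at the same place would begin to separate these changes, and how far compound 4 lies beyond the limit cannot be read from these data.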